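From thiophene to iodine on a nucleoside scaffold

A few compounds are considered here, and "the series" means these few. Any claim that something is new, unique, unknown or untested is made for them only; others in the source may bear on it.

Compound 1, `COc1ncnc2c1c(-c1ccoc1)cn2[C@@H]1O[C@H](CO)[C@@H](O)[C@H]1O`, gives 1790 nM in a functional assay on HeLa S3 cells (Homo sapiens) for antiproliferative activity, read by XTT assay, with a stated time of 72 h; a lower number here means a stronger inhibitor, a higher number a weaker inhibitor. Compound 2, `COc1ncnc2c1c(-c1cccs1)cn2[C@@H]1O[C@H](CO)[C@@H](O)[C@H]1O`, gives 1760 nM. Compound 3, `CN(C)c1ncnc2c1c(-c1cccs1)cn2[C@@H]1O[C@H](CO)[C@@H](O)[C@H]1O`, reaches only the assay limit of > 20000 nM.

Compound 2 holds the lowest of the two numbers, with compound 1 within the scatter of it. The step to compound 4, `COc1ncnc2c1c(I)cn2[C@@H]1O[C@H](CO)[C@@H](O)[C@H]1O`, is iodo in place of thiophen-2-yl on an aromatic carbon. Among the measured compounds shown here, no measured step replaces the aryl group with a halogen. The exchange of one five-membered aromatic ring for another, a 1.0-fold lower number from compound 1 to compound 2 (0.01 log units; within the scatter), stayed within the scatter, whereas an at least 11-fold higher number from compound 2 to compound 3 (1.05 log units; beyond the scatter) concerned a different position and was large. For compound 4 a step of a 1.7-fold higher number from compound 2 to compound 4 (0.23 log units; within the scatter) is therefore expected, modest and toward a higher number. Compound 4 is estimated at 3000 nM, within 800 nM to 12000 nM.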

Compound 4, half-maximal inhibitory concentration: 14300 nM
For compound 4 the middle estimate is 4.8-fold (0.68 log units) below the measured one; the whole stated range lies below it.
By their numbers in this assay, from the lowest: compounds 2 and 1 (each within the scatter of the next); then compound 4. At a limit, above all of these: compound 3.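

In this assay, the aromatic carbon two ring bonds from the ring nitrogen proved sensitive to a change of group: replacing the aromatic ring with iodo gave an 8.1-fold higher number from compound 2 to compound 4 (0.91 log units; beyond the scatter), and likewise an 8.0-fold higher number from compound 1 to compound 4 (0.90 log units; beyond the scatter). The earlier exchange of one five-membered aromatic ring for another had stayed within the scatter, so it had not shown this sensitivity. Nothing given here explains the difference.

From the compounds shown here alone, what remains open is how a phenyl ring, a chlorine or an amine at this carbon would compare. Going by these compounds, it is also open whether the iodo step would be similar with dimethylamino in place of methoxy.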